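Compound 3 to compound 4: methoxy gives way to difluoro

The source may report more compounds than this note shows. Statements on the series, on what has been measured and on what is new or still open speak of the compounds shown alone.

compound 1 `O[C@]1(Cc2cc(-c3cn[nH]c3)on2)CC[C@H](Cc2ccc(Cl)cc2)CC1` gives 72.8%
compound 2 `O[C@]1(Cc2cc(-c3cn[nH]c3)on2)CC[C@H](Cc2ccc(F)cc2)CC1` gives 78%
compound 3 `COc1ccc(C[C@H]2CC[C@](O)(Cc3cc(-c4cn[nH]c4)on3)CC2)cc1` gives 23.7%

In an ADME assay on the whole organism (strain Sprague-Dawley) for pharmacokinetics, with Rattus norvegicus as the target, using cassette dosing, at a dose of 1 mg/kg by the oral route (a lower number here means that a smaller share of the oral dose reaches the circulation, a higher number that a larger share of the oral dose reaches the circulation), compound 3 gives 23.7% and stands lowest of the three measured compounds, with both of its gaps to the others beyond the scatter. Compound 4 `O[C@]1(Cc2cc(-c3cn[nH]c3)on2)CC[C@H](Cc2ccc(F)c(F)c2)CC1` is still unmeasured. It carries 3,4-difluorophenyl in place of 4-methoxyphenyl, on a saturated chain carbon bound to a saturated ring carbon (3,4-difluorophenyl in place of 4-methoxyphenyl on a saturated chain carbon bound to a saturated ring carbon), and the rest of the structure is unchanged.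

Going by the values given here, three measured steps bear on this change. Methoxy in place of chloro gave a number 49.1 percentage points lower from compound 1 to compound 3 (beyond the scatter) and methoxy in place of fluoro gave a number 54.3 percentage points lower from compound 2 to compound 3 (beyond the scatter) in the same series. Fluoro in place of chloro gave a number 5.2 percentage points higher from compound 1 to compound 2 (within the scatter) and so separated neither halogen compound from the other. Compound 4 leaves the methoxy group behind and carries fluoro, so a large rise is expected in this assay, close to those two drops in reverse. Among the compounds with values here, no measured compound carries a second fluoro on the ring, which leaves the range wide. The estimated change is a number 44.3 percentage points higher from compound 3 to compound 4 (beyond the scatter) in this account. Compound 4 is expected at 68% within a range from 45% to 88% in this estimate.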

Compound 4, oral bioavailability: 67.5%
For compound 4 the middle estimate is 0.5 percentage points above the measured one; measured number inside the range.
By their numbers in this assay, from the lowest: compound 3; then compounds 4, 1 and 2 (each within the scatter of the next, the first and the last beyond it).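

In this assay, the exchange of 4-methoxyphenyl for 3,4-difluorophenyl on a saturated chain carbon bound to a saturated ring carbon gives a number 43.8 percentage points higher from compound 3 to compound 4 (beyond the scatter), which shows that the low number of compound 3 does not carry over once the methoxy group has left this position. Going by these compounds alone, the second fluoro brings something the earlier compounds did not show: it gives a number 10.5 percentage points lower from compound 2 to compound 4 (beyond the scatter), a modest step and the only one beyond the scatter among the three halogen-bearing compounds. Against the chloro compound the same ring gives a number 5.3 percentage points lower from compound 1 to compound 4 (within the scatter), so 3,4-difluorophenyl and 4-chlorophenyl are not told apart at this position, and all three halogen-bearing compounds stand clear of compound 3.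

The data offer no measurement that accounts for the fall with methoxy or for the modest step with the second fluoro. Also open, from the compounds shown here alone, is how this ring would read in this assay if it carried an amine, a carboxylic acid or a nitrile, and whether a hydroxy group would behave like the methoxy group of compound 3.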